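Replacing benzamido on compound 3

The compounds below may be only part of what the source reports. "The series", "measured", "known", "first", "only" and "open" are said of these compounds alone.

Measured in a functional assay on HepG2 cells (Homo sapiens) for antiproliferative activity, read by MTT assay, with a stated time of 48 h; on this read-out lower numbers stand for stronger inhibition and higher numbers for weaker inhibition:
compound 1 `Cc1ccc(C(=O)Nc2ccc(Cl)cc2C(N)=O)cc1`: 21 ug/mL
compound 2 `Cc1ccc(-c2nc3ccc(Cl)cc3c(=O)[nH]2)cc1`: 9.86 ug/mL
compound 3 `Cc1ccc(-c2nc(NC(=O)c3ccccc3)c3cc(Cl)ccc3n2)cc1`: 17.5 ug/mL

Compound 3, at 17.5 ug/mL, lies within the scatter of compound 1 at 21 ug/mL and also within the scatter of compound 2 at 9.86 ug/mL. Compound 4 `Cc1ccc(-c2nc(SCCO)c3cc(Cl)ccc3n2)cc1` has yet to be measured. It carries (2-hydroxyethyl)sulfanyl in place of benzamido on an aromatic carbon, next to the ring nitrogen ((2-hydroxyethyl)sulfanyl in place of benzamido on an aromatic carbon).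

Within the data shown here, no two measured compounds differ in one place only, so the data offer no direct guide to this change. In this assay, no step beyond the scatter is expected, and this expectation rests only on the small spread around compound 3 at 17.5 ug/mL. The estimated step is a 1.3-fold lower number from compound 3 to compound 4 (0.10 log units; within the scatter), which is a cautious expectation and not a firm prediction of direction. The expected value for compound 4 is 14 ug/mL, with an estimated range from 6 ug/mL to 35 ug/mL.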

Compound 4, half-maximal inhibitory concentration: 9.04 ug/mL
Compound 4: the middle estimate sits 1.5-fold (0.19 log units) above what was measured, within the range that was stated.
By their numbers in this assay, from the lowest: compounds 4, 2, 3 and 1 (each within the scatter of the next, the first and the last beyond it).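

In this assay the first pair differing in one place only gives a 1.9-fold lower number from compound 3 to compound 4 (0.29 log units; within the scatter) when (2-hydroxyethyl)sulfanyl replaces benzamido on the aromatic carbon next to the ring nitrogen. At this position, then, a group with no ring and fewer heavy atoms keeps the number within the scatter of compound 3, so the six-membered aromatic ring of benzamido is not required for that. Nothing measured here accounts for this outcome.

Among these compounds, the single pair cannot separate the contributions of the sulfur, the hydroxyl and the chain length. Going by these compounds, it remains open how a simple amine, a carboxylic acid or a longer hydroxyalkylsulfanyl chain at this position would read, and whether any group here gives a step beyond the scatter.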